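The source may hold more compounds than are shown below. What is called first, only, known or untested is meant among the compounds shown, and "the series" means these compounds.

Measured so far:
compound 1 `COc1ccc(CNc2cc(OC)c(OC)c(OC)c2)cc1Br` — 39800 nM
compound 2 `C/C=C/C(=O)N(Cc1ccc(OC)c(Br)c1)c1cc(OC)c(OC)c(OC)c1` — 10500 nM
compound 3 `COc1cc(NCc2cccc(O)c2)cc(OC)c1OC` — 71300 nM

In a functional assay on KYSE-450 cells (Homo sapiens) for inhibition, read by MTT assay, with a stated time of 48 h (a higher number here means a weaker inhibitor, a lower number a stronger inhibitor), compound 2 gives the lowest number of the three, with compound 1 and compound 3 both beyond the scatter above it. Within the data shown here, the only measured step, a 3.8-fold lower number from compound 1 to compound 2 (0.58 log units; beyond the scatter), concerns the substituent on the nitrogen and so does not bear on the change now in question. Compound 4 `C/C=C/C(=O)N(Cc1ccc(OC)c(F)c1)c1cc(OC)c(OC)c(OC)c1` differs from compound 2 by fluoro in place of bromo on an aromatic carbon. Among the measured compounds shown here, no measured pair varies this halogen, so no step informs the expectation directly. The change is expected to be small, a 1.3-fold higher number from compound 2 to compound 4 (0.12 log units; within the scatter), with the number drifting upward at most within the scatter. Compound 4 is therefore estimated at 14000 nM, in the range 6000 nM to 35000 nM.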

Compound 4, half-maximal inhibitory concentration: 1400 nM
Compound 4: the middle estimate sits 10-fold (1.00 log units) above what was measured, outside the stated range (below it).
By their numbers in this assay, from the lowest: compound 4; then compound 2; then compounds 1 and 3 (each within the scatter of the next).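

In this assay the exchange of bromo for fluoro ortho to a methoxy group gives a 7.5-fold lower number from compound 2 to compound 4 (0.88 log units; beyond the scatter) and shows that the identity of this halogen matters in the amide pair. Both groups count as one heavy atom with no hydrogen-bond donors or acceptors, so those counts do not separate the pair. No measurement at hand explains the step.

Still open, as far as these compounds go, is how chloro, hydrogen or methyl would read at this position. Also open, from the compounds shown here alone, is whether fluoro in place of bromo gives a similar step without the (prop-1-en-1-yl)carbonyl group, as in compound 1.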